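This account rests on a few compounds, and the source may have more. Where it says the series, first, only, none or still open, it means among the compounds named here.

Measured so far, in an ADME assay on Vero cells (Chlorocebus sabaeus) for cytotoxicity, read by neutral red uptake, tested at 49 ug/mL; a higher number here means a weaker effect of the compound at the concentration tested, a lower number a stronger effect:
- compound 1 `O=C1CSC(c2cccc(Cl)c2)N1CCN1CCCCC1` gives 100%
- compound 2 `O=C1CSC(c2ccc(O)cc2)N1CCN1CCCCC1` gives 96%
- compound 3 `Cc1ccc(C2SCC(=O)N2CCN2CCCCC2)cc1` gives 100%

Compound 3 sits level with compound 1 at the digits shown, and the remaining step is a number 4 percentage points higher from compound 2 to compound 3 (within the scatter), so all three numbers lie within the ordinary scatter of one another. The unmeasured compound 4 `O=C1CSC(c2ccc(F)cc2)N1CCN1CCCCC1` differs from compound 3 by fluoro in place of methyl on an aromatic carbon. The steps that touch this aromatic ring, no change at the digits printed from compound 1 to compound 3 (within the scatter) and a number 4 percentage points higher from compound 2 to compound 3 (within the scatter), were both within the scatter, as was a number 4 percentage points lower from compound 1 to compound 2 (within the scatter). On that basis no movement beyond the scatter is expected in this assay, and the step is estimated as no change at the digits printed from compound 3 to compound 4 (within the scatter). Compound 4 is therefore expected to give 100%, in the range 90% to 102%.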

Compound 4, a percentage reported as activity, at one concentration (the size of the read-out at that concentration, not a potency): 100%
Compound 4: middle estimate and measured number agree at the digits printed, and the stated range covers the measured number.
By their numbers in this assay, from the lowest: compounds 2, 1, 3 and 4 (each within the scatter of the next).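

In this assay, the 4-fluorophenyl compound adds a third group at the para place and stays with the others: fluoro in place of methyl gives (no change at the digits printed from compound 3 to compound 4 (within the scatter)), fluoro in place of hydroxy gives (a number 4 percentage points higher from compound 2 to compound 4 (within the scatter)), and the swap from 3-chlorophenyl gives (no change at the digits printed from compound 1 to compound 4 (within the scatter)). Across these four compounds, then, no aromatic group shown stands apart from the rest. Nothing measured alongside these numbers explains them.

As far as these compounds go, whether an amine or a carboxylic acid on this aromatic ring would give a number beyond the scatter in this assay stays open. From the compounds shown here alone, the shared core is the same throughout, so changes to it also remain untested here.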